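A few compounds are considered here, and "the series" means these few. Any claim that something is new, unique, unknown or untested is made for them only; others in the source may bear on it.

Measured compounds:
- compound 1, `N=C(N)NCCC[C@H](NC(=O)CN(c1nc(Cl)nc2[nH]cnc12)C1CC1)C(=O)O`: 45.4%
- compound 2, `N=C(N)NCCC[C@H](NC(=O)CN(c1nc(Cl)nc2[nH]cnc12)C1CC1)C(=O)OCc1ccccc1`: 23.2%
- compound 3, `O=C(CN(c1nc(Cl)nc2[nH]cnc12)C1CC1)N[C@@H](CCC(=O)OCc1ccccc1)C(=O)OCc1ccccc1`: 52.8%

In a functional assay on the whole organism (Tail, strain ICR) with Mus musculus as the target, in the tail flick test, with a stated time of 30 min, at a dose of 25 umol/kg by the oral route (on this read-out higher numbers stand for a stronger effect at the one dose given and lower numbers for a weaker effect), compound 1 gives 45.4%, the second highest of the three numbers; compound 3 is nearest, within the scatter, and compound 2 lies furthest, with a number 22.2 percentage points lower from compound 1 to compound 2 (beyond the scatter). Compound 4, `CSCC[C@H](NC(=O)CN(c1nc(Cl)nc2[nH]cnc12)C1CC1)C(=O)O`, is not yet measured. It differs from compound 1 in one place: a group of 2 heavy atoms (1 carbon, 1 sulfur; no ring) in place of a group of 5 heavy atoms (2 carbon, 3 nitrogen; no ring), on a saturated chain carbon, three bonds along the chain from an amide-type nitrogen and a carbonyl carbon.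

Of the measured steps only a number 29.6 percentage points higher from compound 2 to compound 3 (beyond the scatter) concerns the same place, where a different group took the place of the same group of 5 heavy atoms, yet that step was made between two benzyl esters and not between acids. The step from compound 1 to compound 2 changes the oxygen next to the carbonyl group, not the side chain, and does not bear on compound 4. On this thin basis a small rise or no change beyond the scatter is expected: for compound 4 an estimated a number 4.6 percentage points higher from compound 1 to compound 4 (within the scatter) in this assay, giving an expected value of 50%, in the range 30% to 70%.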

Compound 4, a percentage reported as activity, at one dose (the size of the read-out at that dose, not a potency): 20.4%
Compound 4: middle estimate off by 29.6 percentage points, on the high side; measured number outside the range, below it.
By their numbers in this assay, from the lowest: compounds 4 and 2 (each within the scatter of the next); then compounds 1 and 3 (each within the scatter of the next).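

In this assay, putting methylsulfanyl in place of the group of 5 heavy atoms while the carboxylic acid stays gives a number 25 percentage points lower from compound 1 to compound 4 (beyond the scatter), so the side chain at this place matters when the acid is kept. The only earlier step at this place, a number 29.6 percentage points higher from compound 2 to compound 3 (beyond the scatter), ran the other way, with a group of 10 heavy atoms entering on a benzyl ester, so changes here do not share one direction across the compounds shown. Nothing available explains why the number fell with methylsulfanyl.

The compounds shown leave open whether a primary amine or a carboxylic acid at this place, in a compound that keeps the free acid, would hold the number near that of compound 1. They also leave open whether a longer chain carrying the sulfur would do so, and how methylsulfanyl behaves on a benzyl ester.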